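The source may hold more compounds than are shown below. What is called first, only, known or untested is meant among the compounds shown, and "the series" means these compounds.

Compound 1 `Fc1ccc(-c2ccc3c(NCCCNCc4ccco4)ccnc3c2)cc1` is the starting point. In a physicochemical assay for acid dissociation, compound 1 gives 9.47, level with compound 2 `COc1cccc(CNCCCNc2ccnc3cc(-c4ccc(F)cc4)ccc23)c1O` at 9.47; together these are the highest of the three numbers, though the gap to compound 3 `COc1cccc(Oc2ccc3c(NCCCNCc4cccc(OC)c4O)ccnc3c2)c1`, which gives 9.28, lies within the scatter. The change to compound 4 `CN(C)c1cccc(Oc2ccc3c(NCCCNCc4ccco4)ccnc3c2)c1` is 3-(dimethylamino)phenoxy in place of 4-fluorophenyl on an aromatic carbon. Among the compounds with values here, two measured steps bear on it. The first, no change at the digits printed from compound 1 to compound 2 (within the scatter), altered the group on the chain carbon; the second, a number 0.19 log units lower from compound 2 to compound 3 (within the scatter), put 3-methoxyphenoxy in place of the same 4-fluorophenyl and is the closer match. Neither moved the read-out beyond the scatter, so no shift beyond the scatter is expected here. Compound 4 is therefore expected to give about 9.35, within 9 to 9.7. The step this implies is estimated as a number 0.12 log units lower from compound 1 to compound 4 (within the scatter).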

Compound 4, acid dissociation constant: 9.28
Compound 4: middle estimate off by 0.07 log units, on the high side, within the range that was stated.
By their numbers in this assay, from the lowest: compounds 3, 4, 1 and 2 (each within the scatter of the next).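

In this assay, putting 3-(dimethylamino)phenoxy in place of 4-fluorophenyl on this aromatic carbon gives a number 0.19 log units lower from compound 1 to compound 4 (within the scatter). So a group of 10 heavy atoms, including a nitrogen and an oxygen, can replace one of 7 without moving the read-out beyond the scatter, and with furan-2-yl on the chain as well as with 2-hydroxy-3-methoxyphenyl. No measurement here accounts for this. Still open, from the compounds shown here alone, is whether a carboxylic acid at this aromatic carbon, or a longer chain in the core of compound 1, would move the read-out beyond the scatter.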